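The source may hold more compounds than are shown below. What is called first, only, known or untested is meant among the compounds shown, and "the series" means these compounds.

For the measured compounds named here, compound 1 `C[C@@H](CNc1ccc(Cl)cc1)[C@H]1CC[C@@H](c2ccnc3ccc(F)cc32)CC1` supplies the only plain number here: in an assay on blood for inhibition of Indoleamine 2,3-dioxygenase 1 (Homo sapiens), read by mass spectrometry, with stated times of 4 h and 18 h (a lower number here means a stronger inhibitor, a higher number a weaker inhibitor), compound 1 gives 44 nM. Compound 2 `C[C@@H](NCc1ccc(Cl)cc1)[C@H]1CC[C@@H](c2ccnc3ccc(F)cc32)CC1` reaches only a limit of this assay, > 1000 nM. Going by the values given here, the single measured step, an at least 22-fold higher number from compound 1 to compound 2 (1.35 log units; beyond the scatter), shows how sharply this assay responds to a rearrangement around the amine. Compound 3 `C[C@@H](CNC(=O)c1ccc(Cl)cc1)[C@H]1CC[C@@H](c2ccnc3ccc(F)cc32)CC1` changes compound 1 differently: (4-chlorophenyl)carbonyl in place of 4-chlorophenyl on an amine nitrogen. Among the compounds with values here, no measured step covers this exact change, so the expectation is uncertain. Because an at least 22-fold higher number from compound 1 to compound 2 (1.35 log units; beyond the scatter) was so large, a weakening step is expected, a 6.8-fold higher number from compound 1 to compound 3 (0.83 log units; beyond the scatter). Compound 3 is thus estimated at 300 nM, within 60 nM to 2000 nM.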

Compound 3, half-maximal inhibitory concentration: 158 nM
Estimate against measurement, compound 3: 1.9-fold (0.28 log units) above; measured number inside the range.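

Placing (4-chlorophenyl)carbonyl in place of 4-chlorophenyl on this amine nitrogen gives a 3.6-fold higher number from compound 1 to compound 3 (0.56 log units; beyond the scatter) in this assay. This is a real loss, yet the resulting amide still gives a plain number, so this nitrogen can carry a carbonyl and the compound keeps measurable inhibition. Compound 2 alone stays at a limit: the limit of > 1000 nM in this assay, at which 1 of the 3 values shown sits.

With a single such change, the compounds shown leave open how much of this step belongs to the carbonyl itself. Also open, as far as these compounds go, is how a (4-chlorophenyl)sulfonyl group on the same amine nitrogen would read.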